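The source may report more compounds than this note shows. Statements on the series, on what has been measured and on what is new or still open speak of the compounds shown alone.

In a functional assay on PC-3 cells (Homo sapiens) for antiproliferative activity, read by MTT assay, with a stated time of 48 h (on this read-out lower numbers stand for stronger inhibition and higher numbers for weaker inhibition), three compounds with a shared core have been measured. Compound 1 `O=C(Nc1cc(Sc2ncn[nH]2)c(O)c2ccccc12)c1ccc([N+](=O)[O-])cc1` gives 53500 nM. Compound 2 `O=C(Nc1cc(Sc2ncn[nH]2)c(O)c2ccccc12)c1cccc([N+](=O)[O-])c1` gives 26900 nM, the step being a 2.0-fold lower number from compound 1 to compound 2 (0.30 log units; within the scatter). Compound 3 `O=C(/C=C/c1ccccc1)Nc1cc(Sc2ncn[nH]2)c(O)c2ccccc12` in this assay reports only a limit, > 100000 nM. Compound 3 thus stands beyond what this assay resolves; the step of an at least 1.8-fold higher number from compound 1 to compound 3 (0.27 log units; that floor lies within the scatter), whereas an at least 3.7-fold higher number from compound 2 to compound 3 (0.57 log units; beyond the scatter). Compound 4 `O=C(/C=C/c1ccc(Cl)cc1)Nc1cc(Sc2ncn[nH]2)c(O)c2ccccc12` awaits measurement. It differs from compound 3 by chloro in place of hydrogen on an aromatic carbon. Among the compounds with values here, no measured step swaps chloro for hydrogen, so none bears directly on this change; the two steps that bring in the 2-phenylethenyl arm, an at least 1.8-fold higher number from compound 1 to compound 3 (0.27 log units; that floor lies within the scatter) and an at least 3.7-fold higher number from compound 2 to compound 3 (0.57 log units; beyond the scatter), only show that arm ending at the limit. With nothing pointing either way, compound 4 is expected to stay close to where compound 3 lies, and the step of a number no higher from compound 3 to compound 4 (the limit leaves the size open) is estimated to remain within the scatter. For compound 4 the expected value in this assay is 100000 nM, with a likely range from 30000 nM to 300000 nM, and a real chance that again only a limit is reported.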

Compound 4, half-maximal inhibitory concentration: > 100000 nM
Compound 4: a limit, no number; the forecaster's own chance of this, stated with the estimate: 60%; the middle value sits exactly at the limit.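

In this assay, chloro on the aromatic carbon para to a large group does not bring the value back within what the assay can read: compound 4 reports only a limit, > 100000 nM. The 2-(4-chlorophenyl)ethenyl arm therefore sits where the 2-phenylethenyl arm sat, with an at least 3.7-fold higher number from compound 2 to compound 4 (0.57 log units; beyond the scatter) and an at least 1.8-fold higher number from compound 1 to compound 4 (0.27 log units; that floor lies within the scatter). The step between the two arms themselves cannot be read, because both compounds stop at the same limit: the limit of > 100000 nM in this assay, at which 2 of the 4 values shown sit.

On these data alone, how far either compound lies past that limit remains unknown, so any effect of chloro here could be hidden. Also open, as far as these compounds go, is whether an amine or a methoxy group on that same aromatic carbon would give a readable number.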